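Acetyl in Place of Methoxy on a Shared Core

A few compounds are considered here, and "the series" means these few. Any claim that something is new, unique, unknown or untested is made for them only; others in the source may bear on it.

Compound 2 `COc1ccc(-c2ccc3ncn(-c4cc(OC)c(OC)c(OC)c4)c3c2)cc1` stands at the edge of what can be read: in a functional assay on A549 cells (Homo sapiens) for antiproliferative activity, read by MTT assay, with a stated time of 72 h (on this read-out higher numbers stand for weaker inhibition and lower numbers for stronger inhibition), compound 2 gives > 10000 nM, a limit of the assay rather than a number. Compound 3 `COc1cc(-n2cnc3ccc(-c4ccc(C)cc4F)cc32)cc(OC)c1OC` gives > 10000 nM in this assay, also a limit. Compound 1 `COc1cc(-n2cnc3ccc(-c4cccc(F)c4)cc32)cc(OC)c1OC` gives 5270 nM in this assay. The steps of an at least 1.8-fold higher number from compound 1 to compound 2 (0.27 log units; that floor lies within the scatter) and an at least 1.8-fold higher number from compound 1 to compound 3 (0.27 log units; that floor lies within the scatter) show only floors, and a step that the two limits leave unreadable from compound 2 to compound 3 cannot be read, since two values sit at the limit of > 10000 nM in this assay, at which 2 of the 3 values shown sit. Compound 4 `COc1cc(-n2cnc3ccc(-c4ccc(C(C)=O)cc4)cc32)cc(OC)c1OC` differs from compound 2 by acetyl in place of methoxy on an aromatic carbon. For the measured compounds named here, no measured step involves an acetyl group, so the change is uncharted. Compound 4 is estimated at 9000 nM in this assay, between 3000 nM and 30000 nM. A step of an at least 1.1-fold lower number from compound 2 to compound 4 (0.04 log units; that floor lies within the scatter) is therefore expected, if one can be read at all.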

Compound 4, half-maximal inhibitory concentration: 2510 nM
Estimate against measurement, compound 4: 3.6-fold (0.55 log units) above; measured number below the stated range.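

In this assay, for the compounds shown here, acetyl in place of methoxy gives an at least 3.9-fold lower number from compound 2 to compound 4 (0.60 log units; beyond the scatter) and is the first change at this position with a step clearly beyond the scatter. The 4-acetylphenyl group also gives an at least 3.9-fold lower number from compound 3 to compound 4 (0.60 log units; beyond the scatter) and a 2.1-fold lower number from compound 1 to compound 4 (0.32 log units; beyond the scatter) so compound 4 carries the lowest number of the four. The two steps from the limit compounds remain floors, and the step between compound 2 and compound 3 cannot be read: the limit of > 10000 nM in this assay, at which 2 of the 4 values shown sit.

From the compounds shown here alone, whether an amine or a carboxylic acid in the same place would match acetyl stays open. So does the effect of a longer chain on the carbonyl.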